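From cyclopentyl to a sulfone ring on the aromatic nitrogen

The compounds below may be only part of what the source reports. "The series", "measured", "known", "first", "only" and "open" are said of these compounds alone.

The two measured compounds share one core and differ only in the saturated ring on an aromatic nitrogen. Compound 1 `Cc1cc(NC(=O)Cn2nnc(-c3ccccc3)n2)n(C2CCOCC2)n1` carries oxan-4-yl there, and in an assay on HEK293 cells for activation of Kir3.1/Kir3.2 (Homo sapiens), read by thallium flux (on this read-out lower numbers stand for an effect already at smaller amounts and higher numbers for an effect only at larger amounts of compound), compound 1 gives 435 nM. Compound 2 `Cc1cc(NC(=O)Cn2nnc(-c3ccccc3)n2)n(C2CCCC2)n1` carries cyclopentyl, and in this assay compound 2 gives 163 nM, the lower of the two numbers; the step of a 2.7-fold lower number from compound 1 to compound 2 (0.43 log units; beyond the scatter) lies beyond the scatter. Compound 3 `Cc1cc(NC(=O)Cn2nnc(-c3ccccc3)n2)n(C2CCS(=O)(=O)CC2)n1` takes the next step: 1,1-dioxothian-4-yl in place of cyclopentyl on an aromatic nitrogen. Among the measured compounds shown here, only one measured step bears on it, a 2.7-fold lower number from compound 1 to compound 2 (0.43 log units; beyond the scatter), in which oxan-4-yl gave way to cyclopentyl and the number fell. Compound 3 moves in the opposite direction, from cyclopentyl back to a six-membered ring with a hetero atom, so a higher number than for compound 2 is expected, plausibly at or beyond that of compound 1, though a single step is thin support. For compound 3 the expected value in this assay is 600 nM, within 250 nM to 1500 nM, an expected step of a 3.7-fold higher number from compound 2 to compound 3 (0.57 log units; beyond the scatter).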

Compound 3, half-maximal effective concentration: > 10000 nM
Compound 3 was reported as a limit; the forecaster's own chance of this, stated with the estimate: 5%; middle value at least 16-fold (1.22 log units) from the limit.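

Compound 3 is reported only as a limit of the assay: the limit of > 10000 nM in this assay, at which 1 of the 3 values shown sits. At this place on an aromatic nitrogen, 1,1-dioxothian-4-yl gives an at least 61-fold higher number from compound 2 to compound 3 (1.78 log units; beyond the scatter) and an at least 22-fold higher number from compound 1 to compound 3 (1.36 log units; beyond the scatter), so in this assay a position that had shown only a modest step between two saturated rings can carry a far larger one. The second of these steps keeps a six-membered non-aromatic ring with one hetero atom, so ring size alone does not separate compound 1 from compound 3.

The limit leaves open how large the steps to compound 3 really are. The compounds shown also leave open whether a ketone at the same ring position, or a ring amine, would be tolerated here as oxan-4-yl is.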